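Second Acyloxymethyl Ester in a Buffer Stability Series

The compounds below may be only part of what the source reports. "The series", "measured", "known", "first", "only" and "open" are said of these compounds alone.

Compound 1 `CCOC(=O)C1=C(S[C@@H]2CN[C@H](C(=O)Nc3cccc(C(=O)O)c3)C2)[C@H](C)[C@@H]2[C@@H]([C@@H](C)O)C(=O)N12` and compound 2 `CCC(CC)C(=O)OCOC(=O)C1=C(S[C@@H]2CN[C@H](C(=O)Nc3cccc(C(=O)O)c3)C2)[C@H](C)[C@@H]2[C@@H]([C@@H](C)O)C(=O)N12` share the same core and differ only in the ester group on it. In a physicochemical assay for metabolic stability, read by LC-MS, in phosphate buffer, with a stated time of 3 h, at pH 7.4, tested at 50 uM (on this read-out higher numbers stand for a more stable compound and lower numbers for a less stable compound), compound 1 gives > 95%, which is a limit of the assay and not a number. In this assay compound 2 gives > 95%, likewise a limit of the assay. The step that the two limits leave unreadable from compound 1 to compound 2 is therefore of unreadable size, as the limit of > 95% in this assay, at which 2 of the 2 values shown sit, shows both values sitting at the same limit. Compound 3 `CCC(CC)C(=O)OCOC(=O)C1=C(S[C@@H]2CN[C@H](C(=O)Nc3cccc(C(=O)OCOC(=O)C(CC)CC)c3)C2)[C@H](C)[C@@H]2[C@@H]([C@@H](C)O)C(=O)N12` differs from compound 2 by (((pentan-3-yl)carbonyl)oxy)methyl in place of hydrogen on an oxygen next to a carbonyl group. Within the data shown here, the only measured step, a step that the two limits leave unreadable from compound 1 to compound 2, concerns a related ester change and gives no readable size. The expected step is a number no higher from compound 2 to compound 3 (the limit leaves the size open) in this assay, none beyond the scatter. Compound 3 is expected to give 95% in this assay, with a range from 85% to 100%, most likely reported again as a limit.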

Compound 3, percent of the compound remaining: > 95%
Compound 3 ended at the assay's limit; the forecaster's own chance of this, stated with the estimate: 70%; the middle value lies on the limit itself.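

No new step can be read between compound 2 and compound 3, because both stand at the same limit, which is not a number: the limit of > 95% in this assay, at which 3 of the 3 values shown sit.

The compounds shown leave open whether the (((pentan-3-yl)carbonyl)oxy)methyl group of compound 3 changes the percent remaining at all, and how compound 1, compound 2 and compound 3 rank.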